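A few compounds are considered here, and "the series" means these few. Any claim that something is new, unique, unknown or untested is made for them only; others in the source may bear on it.

Working notes on the series.

Compound 1 `COC(=O)c1sc2cc(C#Cc3ccc(OC)cc3)cnc2c1N` is the reference point: in a functional assay on NCI-H460 cells (Homo sapiens) for inhibition, read by sulforhodamine B assay, with a stated time of 48 h (on this read-out lower numbers stand for stronger inhibition of growth and higher numbers for weaker inhibition of growth), compound 1 gives 320 nM. Compound 2 `COC(=O)c1sc2cc(C#Cc3cccnc3)cnc2c1N` carries pyridin-3-yl in place of 4-methoxyphenyl on the triple-bonded carbon. In this assay compound 2 gives only a limit, > 150000 nM, so its true number is not known. Compound 2 thus sits at the limit of > 150000 nM in this assay, at which 1 of the 2 values shown sits, and the measured step is an at least 460-fold higher number from compound 1 to compound 2 (2.67 log units; beyond the scatter).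

Compound 3 `COC(=O)c1sc2cc(C#Cc3ccc(F)cc3)cnc2c1N` is not yet measured. Its change from compound 2 is 4-fluorophenyl in place of pyridin-3-yl on a triple-bonded carbon. Among the measured compounds shown here, the only step that bears on it is the one from compound 1 to compound 2, which went the other way, from a carbon-only ring to the pyridin-3-yl ring, and was large. Since compound 3 returns to a carbon-only six-membered ring as in compound 1, a large step back toward stronger inhibition of growth in this assay is expected, though the 4-fluorophenyl group is not the same as 4-methoxyphenyl and a residual loss is plausible. The estimate implies the step of an at least 160-fold lower number from compound 2 to compound 3 (2.22 log units; beyond the scatter) as the expected outcome. Compound 3 is therefore estimated at 900 nM, with an expected range from 200 nM to 6000 nM.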

Compound 3, concentration for 50% growth inhibition: 24000 nM
Compound 3: the middle estimate sits 27-fold (1.43 log units) below what was measured; measured number outside the range, above it.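

In this assay, a carbon-only ring on the triple-bonded carbon recovers only part of the lost inhibition of growth: replacing pyridin-3-yl with 4-fluorophenyl gives an at least 6.2-fold lower number from compound 2 to compound 3 (0.79 log units; beyond the scatter), whereas fluoro in place of methoxy on an aromatic carbon gives a 75-fold higher number from compound 1 to compound 3 (1.88 log units; beyond the scatter). Across these three compounds, then, the outcome depends on the group carried by the carbon-only ring as well as on the absence of the ring nitrogen. The first step can be read only as a bound, since the value for compound 2 is a limit: the limit of > 150000 nM in this assay, at which 1 of the 3 values shown sits.

How far the methoxy group itself is required remains open, with only methoxy and fluoro shown on the carbon-only ring. Plain phenyl, or an ethoxy, hydroxy or dimethylamino group in place of methoxy, would help separate these possibilities.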